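The source may hold more compounds than are shown below. What is called first, only, known or untested is meant among the compounds shown, and "the series" means these compounds.

In a functional assay on Bel-7402 cells (Homo sapiens) for inhibition, read by MTT assay, with a stated time of 24 h, tested at 100 ug/mL (on this read-out higher numbers stand for more inhibition of growth at the one concentration tested and lower numbers for less inhibition of growth), two compounds have been measured so far. Compound 1 `O=C(CCCCC1CCSS1)Nc1ccccn1` gives 37.6%, and compound 2 `O=C(CCCCC1CCSS1)Nc1cccc2ccccc12` gives 7.22%, which makes compound 2 the lower of the two by a gap beyond the usual scatter. Compound 3 `O=C(CCCCC(S)CCS)Nc1cccc2ccccc12` has yet to be measured. It differs from compound 2 in one place, on a saturated chain carbon, four bonds along the chain from a carbonyl carbon: a group of 5 heavy atoms (3 carbon, 2 sulfur; no ring) in place of a group of 5 heavy atoms (3 carbon, 2 sulfur; one five-membered non-aromatic ring with 2 hetero atoms), on a saturated chain carbon, four bonds along the chain from a carbonyl carbon. Going by the values given here, no measured pair shows the effect of this change, so any expectation remains loose. With compound 2 standing at 7.22%, a small upward move is expected, most likely not beyond the scatter. The expected change is a number 7.8 percentage points higher from compound 2 to compound 3 (within the scatter). For compound 3, the estimated growth inhibition is 15%, with an expected range from 3% to 35%.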

Compound 3, percent growth inhibition at one concentration: "not active" (no number reported)
Compound 3: no number reported; the estimate stays without a comparison.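

Going by these compounds alone, compound 3 is reported as "not active" in this assay without a number, so no step from compound 2 to compound 3 can be read. The compounds shown leave open how far 1,3-disulfanylpropyl in place of the ring shifts growth inhibition. Nothing given here bears on this result.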